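Chloro for methoxy on the aryl group of the pyrimidinone

The source may hold more compounds than are shown below. What is called first, only, known or untested is meant among the compounds shown, and "the series" means these compounds.

Compound 1 `COc1ccc(-c2nc(C)c(C(=O)CSc3nc(-c4ccc(OC)cc4)c(C#N)c(=O)[nH]3)s2)cc1` gives 32.6% in a functional assay on U-87MG ATCC cells for antiproliferative activity against U-87 MG (Homo sapiens), read by MTT assay, with a stated time of 48 h, tested at 50 uM; on this read-out lower numbers stand for a stronger effect and higher numbers for a weaker effect at the one concentration tested.
Compound 2 `COc1ccc(-c2nc(SCC(=O)c3sc(-c4ccc(Cl)cc4)nc3C)[nH]c(=O)c2C#N)cc1` gives 46.3% in this assay.

Compound 1 is the lowest of the two numbers; its nearest neighbour is compound 2, with a number 13.7 percentage points higher from compound 1 to compound 2 (beyond the scatter). Compound 3 `COc1ccc(-c2nc(C)c(C(=O)CSc3nc(-c4cccc(Cl)c4)c(C#N)c(=O)[nH]3)s2)cc1` differs from compound 1 by 3-chlorophenyl in place of 4-methoxyphenyl on an aromatic carbon. Going by the values given here, the one measured step, a number 13.7 percentage points higher from compound 1 to compound 2 (beyond the scatter), also swapped chloro for methoxy, though at a different site, and it was modest and beyond the scatter. A comparable rise is therefore expected for compound 3, a number 10.4 percentage points higher from compound 1 to compound 3 (beyond the scatter), giving an estimated 43% with a range from 28% to 58%.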

Compound 3, a percentage reported as activity, at one concentration (the size of the read-out at that concentration, not a potency): 83.4%
The estimate for compound 3 lay 40.4 percentage points below the measured number; the measured number lies above the stated range.
By their numbers in this assay, from the lowest: compound 1; then compound 2; then compound 3.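

In this assay, 3-chlorophenyl in place of 4-methoxyphenyl on the aromatic carbon ortho to a cyano group gives a number 50.8 percentage points higher from compound 1 to compound 3 (beyond the scatter), a large loss of effect at the one concentration tested. This position therefore responds strongly to substitution, and more so than the site changed in the earlier step, a number 13.7 percentage points higher from compound 1 to compound 2 (beyond the scatter), although the two swaps are not identical. Nothing available here explains the size of this loss.

The step changes both the substituent and its place on the phenyl group, so their contributions cannot be separated. As far as these compounds go, it remains open how 4-chlorophenyl, or a phenyl group carrying an amine or a carboxylic acid, would read at this position.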